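This account rests on a few compounds, and the source may have more. Where it says the series, first, only, none or still open, it means among the compounds named here.

In a functional assay on A549 cells (Homo sapiens) for inhibition, read by sulforhodamine B assay (a higher number here means a weaker inhibitor of growth, a lower number a stronger inhibitor of growth), three compounds with a shared core have been measured. Compound 1 `Cc1ccc2[nH]c(-c3ccc(-c4ccc(-c5ccc(N(C)C)cc5)cc4)cc3)nc2c1` gives 3510 nM, compound 2 `Cc1ccc2[nH]c(-c3ccc(-c4ccc(-c5cccc(Cl)c5)cc4)cc3)nc2c1` gives 2800 nM, and compound 3 `Cc1ccc2[nH]c(-c3ccc(-c4ccc(-c5ccc(C(F)(F)F)cc5)cc4)cc3)nc2c1` gives 3520 nM. Compound 3 thus stands level with the other two, as the measured steps show: a 1.0-fold higher number from compound 1 to compound 3 (0.00 log units; within the scatter) and a 1.3-fold higher number from compound 2 to compound 3 (0.10 log units; within the scatter).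

Compound 4 `Cc1ccc2[nH]c(-c3ccc(-c4ccc(-c5ccc(O)cc5)cc4)cc3)nc2c1` is the next to be read, and it differs from compound 3 by one group: hydroxy in place of trifluoromethyl on an aromatic carbon. In words, this is hydroxy in place of trifluoromethyl on an aromatic carbon. Within the data shown here, the closest precedent is the exchange of dimethylamino for trifluoromethyl, a 1.0-fold higher number from compound 1 to compound 3 (0.00 log units; within the scatter), while the exchange of 3-chlorophenyl for 4-(trifluoromethyl)phenyl gave a 1.3-fold higher number from compound 2 to compound 3 (0.10 log units; within the scatter). Among the measured compounds shown here, no measured compound carries hydroxy, so these steps offer only indirect guidance. Neither step leaves the scatter, so no change beyond it is expected here. The expected step is a 1.2-fold lower number from compound 3 to compound 4 (0.07 log units; within the scatter). For compound 4 the estimated value is 3000 nM, with an expected range from 1300 nM to 6500 nM.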

Compound 4, concentration for 50% growth inhibition: 3520 nM
Compound 4: middle estimate off by 1.2-fold (0.07 log units), on the low side; low and high end bracket the measured number.
By their numbers in this assay, from the lowest: compounds 2, 1, 3 and 4 (each within the scatter of the next).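

In this assay, hydroxy in place of trifluoromethyl gives no shift outside the scatter (no change at the digits printed from compound 3 to compound 4 (within the scatter)), so on this aromatic carbon, para to a large group, a single oxygen bearing a hydrogen-bond donor and acceptor reads level with a four-atom group that has neither. The other two new steps also stay within the scatter (a 1.0-fold higher number from compound 1 to compound 4 (0.00 log units; within the scatter); a 1.3-fold higher number from compound 2 to compound 4 (0.10 log units; within the scatter)), which extends the flat reading among the end groups to a fourth compound, and none of the four goes against it. No evidence is available here to explain this flat reading.

The compounds shown leave open whether a carboxylic acid or a longer ether chain at this same place would also read level with these groups. They also leave open whether a change to the shared core would move the number more than any end group shown here has.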